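This account rests on a few compounds, and the source may have more. Where it says the series, first, only, none or still open, it means among the compounds named here.

Compound 1 `COc1ccc(CCOc2ccc(-c3c(C)nc(C)c([C@H](OC(C)(C)C)C(=O)O)c3N3CCC(C)(C)CC3)cc2)cc1` belongs to a small set of analogues sharing one core and differing only in the group carried on the oxygen on an aromatic ring. In an ADME assay on microsomes from liver (Homo sapiens) for metabolic stability, read by LC-MS, tested at 0.5 uM (on this read-out higher numbers stand for a longer-lived compound and lower numbers for a shorter-lived compound), compound 1 reaches the limit of the assay, giving > 2 h, which is a limit and not a number. Compound 2 `COc1cccc(CCOc2ccc(-c3c(C)nc(C)c([C@H](OC(C)(C)C)C(=O)O)c3N3CCC(C)(C)CC3)cc2)c1` likewise sits at that limit, giving > 2 h in this assay. Among the measured compounds shown here, compound 3 `Cc1nc(C)c([C@H](OC(C)(C)C)C(=O)O)c(N2CCC(C)(C)CC2)c1-c1ccc(OCCc2ccc(F)cc2F)cc1` is the one member with a read number, giving 1.08 h. The step that the two limits leave unreadable from compound 1 to compound 2 cannot be sized, while an at least 1.8-fold lower number from compound 1 to compound 3 (0.26 log units; that floor lies within the scatter) and an at least 1.8-fold lower number from compound 2 to compound 3 (0.26 log units; that floor lies within the scatter) both point downward with a floor that lies within the scatter; both limits sit at the same line, (the limit of > 2 h in this assay, at which 2 of the 3 values shown sit).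

Compound 4 `Cc1nc(C)c([C@H](OC(C)(C)C)C(=O)O)c(N2CCC(C)(C)CC2)c1-c1ccc(OC2COCC2c2ccc(F)cc2)cc1` is not yet measured. It differs from compound 1 as follows: 4-(4-fluorophenyl)oxolan-3-yl in place of 2-(4-methoxyphenyl)ethyl on an oxygen on an aromatic ring. For the measured compounds named here, the only measured step that bears on this change is the one from compound 1 to compound 3, where a fluorinated phenyl replaced the methoxyphenyl and the number fell by an at least 1.8-fold lower number from compound 1 to compound 3 (0.26 log units; that floor lies within the scatter). On that basis compound 4 is expected to show a modest fall, an at least 1.4-fold lower number from compound 1 to compound 4 (0.15 log units; that floor lies within the scatter), with a fair chance that it still reaches the limit. The estimate for compound 4 in this assay is 1.4 h, between 0.6 h and 3 h.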

Compound 4, half-life: 0.783 h
Compound 4: middle estimate off by 1.8-fold (0.25 log units), on the high side; the measured number falls inside the stated range.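

In this assay, among the compounds shown here, 4-(4-fluorophenyl)oxolan-3-yl on an oxygen on an aromatic ring gives the first steps in this set that are beyond the scatter: an at least 2.5-fold lower number from compound 1 to compound 4 (0.40 log units; beyond the scatter), and an at least 2.5-fold lower number from compound 2 to compound 4 (0.40 log units; beyond the scatter). Both steps start from a limit of the assay and so fix only a floor, not a size: the limit of > 2 h in this assay, at which 2 of the 4 values shown sit. Set against 2-(2,4-difluorophenyl)ethyl, the new group cannot be told apart, with a 1.4-fold lower number from compound 3 to compound 4 (0.14 log units; within the scatter), so the two fluorine-bearing groups read alike in this assay, one on an open chain and one on a five-membered non-aromatic ring, while both methoxyphenyl compounds sit at the limit.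

The compounds shown leave open whether the fall follows the oxolane ring or the exchange of methoxy for fluorine, as the step to compound 4 alters both at once, and a 4-(4-methoxyphenyl)oxolan-3-yl group would separate the two. Also open, from the compounds shown here alone, are the true half-lives of compound 1 and compound 2, and how a nitrile in place of the fluorine on the phenyl ring of compound 4 would read.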